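Phenyl in place of trimethoxyphenyl on the enone carbonyl

The source may report more compounds than this note shows. Statements on the series, on what has been measured and on what is new or still open speak of the compounds shown alone.

Measured compounds:
compound 1 `COc1cc(C(=O)/C=C/c2cc(-c3cc(OC)c(OC)c(OC)c3)n3nc(-c4ccccc4)cc3n2)cc(OC)c1OC`, 20500 nM
compound 2 `COc1ccc(-c2cc(/C=C/C(=O)c3cc(OC)c(OC)c(OC)c3)nc3cc(-c4ccccc4)nn23)cc1OC`, 7200 nM
compound 3 `COc1ccc(-c2cc(/C=C/C(=O)c3ccc(C)cc3)nc3cc(-c4ccccc4)nn23)cc1OC`, 17200 nM

In a functional assay on A549 cells (Homo sapiens) for antiproliferative activity, read by MTT assay, with a stated time of 24 h (a higher number here means a weaker inhibitor, a lower number a stronger inhibitor), compound 1 gives the highest of the three numbers. Among the compounds with values here, its nearest neighbour is compound 3, within the scatter; the only step beyond the scatter is a 2.8-fold lower number from compound 1 to compound 2 (0.45 log units; beyond the scatter), brought by a hydrogen in place of a methoxy group on an aromatic carbon. The other measured step, a 2.4-fold higher number from compound 2 to compound 3 (0.38 log units; beyond the scatter), comes from a 4-methylphenyl in place of a 3,4,5-trimethoxyphenyl on the carbonyl carbon.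

Compound 4 `COc1cc(-c2cc(/C=C/C(=O)c3ccccc3)nc3cc(-c4ccccc4)nn23)cc(OC)c1OC` has not been measured in this assay. It differs from compound 1 by phenyl in place of 3,4,5-trimethoxyphenyl on a carbonyl carbon. Within the data shown here, the step that bears on it is the one from compound 2 to compound 3, since there too the 3,4,5-trimethoxyphenyl on the carbonyl carbon gave way to a simpler aryl, and the number rose modestly, beyond the scatter. The entering group here is phenyl rather than 4-methylphenyl, so the carry-over is not exact, but a rise of similar size is the most defensible reading; compound 1 already starts high, so the rise may be softened.

Compound 4 is therefore expected near 40000 nM in this assay, with a range of 15000 nM to 100000 nM. This estimate means a step of a 2.0-fold higher number from compound 1 to compound 4 (0.29 log units; within the scatter).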

Compound 4, half-maximal inhibitory concentration: 18200 nM
The estimate for compound 4 lay 2.2-fold (0.34 log units) above the measured number; low and high end bracket the measured number.
By their numbers in this assay, from the lowest: compound 2; then compounds 3, 4 and 1 (each within the scatter of the next).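

In this assay, a 1.1-fold lower number from compound 1 to compound 4 (0.05 log units; within the scatter) shows that, on the core of compound 1, the 3,4,5-trimethoxyphenyl on the carbonyl carbon can give way to phenyl with no readable change, even though all three of its hydrogen-bond acceptors leave with it. The position therefore does not respond in the same way on both backgrounds: a 2.4-fold higher number from compound 2 to compound 3 (0.38 log units; beyond the scatter) lies beyond the scatter, whereas the present step lies within it, although the entering groups, 4-methylphenyl and phenyl, are not the same, so the two steps are only loosely parallel. No supporting data bear on why the two steps differ.

The compounds shown leave open whether phenyl itself on the carbonyl carbon of the compound 2 background would reproduce the step to 4-methylphenyl, and so whether the difference lies with the background or with the entering group. They also leave open whether this position stays equally unresponsive to groups of another kind, such as a phenyl carrying an amine or a carboxylic acid.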